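One group exchanged on compound 1

The source may report more compounds than this note shows. Statements on the series, on what has been measured and on what is new or still open speak of the compounds shown alone.

In a functional assay on COR-L23 cells (Homo sapiens) for antiproliferative activity, read by CellTiter-Glo, with a stated time of 72 h (on this read-out lower numbers stand for stronger inhibition and higher numbers for weaker inhibition), compound 1 `O=C(Nc1ccc(CN2Cc3ccccc3C2=O)cc1)N1CC(c2cccnc2)C1` gives 9.9 nM and compound 2 `C[C@@H](c1ccc(NC(=O)N2CC(c3cccnc3)C2)cc1)N1Cc2ccccc2C1=O` gives 8 nM on the same read-out, so the two stand level within the scatter. Compound 3 `O=C(Nc1ccc(Cn2c(=O)oc3ccccc32)cc1)N1CC(c2cccnc2)C1` keeps the core of compound 1 and differs in one group: a group of 10 heavy atoms (7 carbon, 1 nitrogen, 2 oxygen; one five-membered aromatic ring with 2 hetero atoms, one six-membered aromatic ring of carbon only) in place of a group of 10 heavy atoms (8 carbon, 1 nitrogen, 1 oxygen; one five-membered non-aromatic ring with 1 hetero atom, one six-membered aromatic ring of carbon only), on a saturated chain carbon bound to an aromatic carbon is the whole change. Among the compounds with values here, only one measured step touches a saturated chain carbon at this place, and it is a 1.2-fold lower number from compound 1 to compound 2 (0.09 log units; within the scatter) when methyl replaces hydrogen there. Within the data shown here, that step offers limited guidance, as no measured compound carries the entering group and the effect of this exchange remains untested. Among the measured compounds shown here, with only that small step to go on, no change beyond the scatter is expected, and the estimated step is a 1.4-fold higher number from compound 1 to compound 3 (0.15 log units; within the scatter) in this assay as a modest shift. For compound 3 the estimated value is 14 nM with an expected range from 4 nM to 50 nM on this measure.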

Compound 3, half-maximal inhibitory concentration: 3.2 nM
Beside the measured number, compound 3's estimate is 4.4-fold (0.64 log units) above it; measured number outside the range, below it.
By their numbers in this assay, from the lowest: compound 3; then compounds 2 and 1 (each within the scatter of the next).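

In this assay, the exchange of one ring group for the other on the saturated chain carbon bound to an aromatic carbon gives a 3.1-fold lower number from compound 1 to compound 3 (0.49 log units; beyond the scatter), a step beyond the scatter, while methyl in place of hydrogen on that carbon gave only a 1.2-fold lower number from compound 1 to compound 2 (0.09 log units; within the scatter), a step within it. The number at this place therefore does respond to the group it carries, even though both groups have 10 heavy atoms and differ in the ring and atom details, including one five-membered aromatic ring with 2 hetero atoms in the entering group. Nothing available explains the shift.

As far as these compounds go, the groups differ in several respects at once, so which difference matters stays open. Also open, from the compounds shown here alone, is how an amine or a carboxylic acid on this carbon would compare, and whether methyl there would have any effect alongside the entering group.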